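Methoxy in place of bromo on compound 2

The source may hold more compounds than are shown below. What is called first, only, known or untested is meant among the compounds shown, and "the series" means these compounds.

In a functional assay on HeLa cells (Homo sapiens) for inhibition, read by MTT assay, with a stated time of 48 h (on this read-out lower numbers stand for stronger inhibition of growth and higher numbers for weaker inhibition of growth), compound 1 `Cn1cc(C2CC(c3ccccc3)=NN2C(=O)c2cccnc2)c2ccccc21` gives > 10000 nM as a limit of the assay, not a number. Compound 2 `Cn1cc(C2CC(c3ccccc3)=NN2C(=O)c2cccnc2)c2cc(Br)ccc21` gives 1730 nM and stands as the higher of the two numbers in hand. The other is from compound 3 `Cn1cc(C2CC(c3ccc(F)cc3)=NN2C(=O)c2cccnc2)c2cc(Br)ccc21` at 630 nM in this assay.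

Compound 4 `COc1ccc2c(c1)c(C1CC(c3ccccc3)=NN1C(=O)c1cccnc1)cn2C` carries methoxy in place of bromo on an aromatic carbon relative to compound 2.

Among the compounds with values here, the closest precedent is an at least 5.7-fold lower number from compound 1 to compound 2 (0.76 log units; beyond the scatter), which comes from bromo in place of hydrogen on that same carbon and shows that this carbon matters. The step of a 2.7-fold lower number from compound 2 to compound 3 (0.44 log units; beyond the scatter) comes from fluoro in place of hydrogen at another place and bears on this change only loosely. No methoxy has yet been measured in the series, so the gain seen with bromo may be only partly kept.

A modest move toward a higher number is expected, with an estimated step of a 2.3-fold higher number from compound 2 to compound 4 (0.36 log units; beyond the scatter) in this assay.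

For compound 4 the estimate is 4000 nM, with an expected range from 1300 nM to 10000 nM.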

Compound 4, concentration for 50% growth inhibition: 3590 nM
Compound 4: the middle estimate sits 1.1-fold (0.05 log units) above what was measured; measured number inside the range.
By their numbers in this assay, from the lowest: compound 3; then compound 2; then compound 4. At a limit, above all of these: compound 1.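

In this assay, the gain at this aromatic carbon is not confined to bromo: methoxy also gives a lower number than hydrogen, with an at least 2.7-fold lower number from compound 1 to compound 4 (0.44 log units; beyond the scatter). Methoxy keeps only part of what bromo gave, with a 2.1-fold higher number from compound 2 to compound 4 (0.32 log units; beyond the scatter), so the order at this carbon runs bromo, then methoxy, then hydrogen. The hydrogen end of that order rests on compound 1, whose > 10000 nM is a limit of the assay and not a number, so the full size of both gains stays unknown: the limit of > 10000 nM in this assay, at which 1 of the 4 values shown sits.

Open, on these data alone, is how an amine, a hydroxyl or a nitrile would rank on this carbon against bromo and methoxy. Also open, as far as these compounds go, is whether the fluoro step seen with bromo in compound 3 would carry over to the methoxy compound 4.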